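The source may report more compounds than this note shows. Statements on the series, on what has been measured and on what is new or still open speak of the compounds shown alone.

Compound 2, `Cc1cc(C)c(S(=O)(=O)c2ccc(C3CCCCC3)cc2)c(C)c1`, is one of two sulfones measured in an assay on isolated protein for antagonist activity at Rap guanine nucleotide exchange factor 4 (Homo sapiens), read by fluorescence and cAMP accumulation; on this read-out lower numbers stand for stronger inhibition and higher numbers for weaker inhibition. In this assay compound 2 gives only a limit, > 300000 nM. Compound 1, `CCCCCc1ccc(S(=O)(=O)c2c(C)cc(C)cc2C)cc1`, likewise gives only a limit in this assay, > 300000 nM. Among the compounds with values here, the single measured step, a step that the two limits leave unreadable from compound 1 to compound 2, therefore cannot be read in size, as the limit of > 300000 nM in this assay, at which 2 of the 2 values shown sit, shows. Compound 3, `Cc1cc(C)c(S(=O)(=O)c2ccc(OCCN)cc2)c(C)c1`, differs from compound 2 by 2-aminoethoxy in place of cyclohexyl on an aromatic carbon. Within the data shown here, no measured step involves such a change, so the step from compound 2 to compound 3 in this assay is estimated without any guide, and a reported limit remains likely; compound 3 is expected to give about 250000 nM, within 40000 nM to 1000000 nM.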

Compound 3, half-maximal inhibitory concentration: > 300000 nM
Compound 3 gave a limit, no number (the forecaster's own chance of this, stated with the estimate: 65%); at least 1.2-fold (0.07 log units) between middle value and limit.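

No new step can be read among compound 1, compound 2 and compound 3, since each gives only a limit: the limit of > 300000 nM in this assay, at which 3 of the 3 values shown sit. The compounds shown leave open how pentyl, cyclohexyl and 2-aminoethoxy rank in this assay.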